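Piperidine Amide in Place of an Aromatic Amine

The source may hold more compounds than are shown below. What is called first, only, known or untested is meant among the compounds shown, and "the series" means these compounds.

Three compounds built on one shared core carrying two benzamidine ethers have been measured. In an assay on isolated protein for inhibition of Trypsin (Homo sapiens), read by fluorescence (on this read-out lower numbers stand for stronger inhibition and higher numbers for weaker inhibition), compound 1 `N=C(N)c1ccc(Oc2ccc(NS(=O)(=O)c3ccc(F)cc3)c(Oc3ccc(C(=N)N)cc3)n2)cc1` gives 1400 nM. Compound 2 `N=C(N)c1ccc(Oc2ccc(C(=O)N[C@H]3CC[C@H](N)CC3)c(Oc3ccc(C(=N)N)cc3)n2)cc1` gives 2000 nM in this assay, and compound 3 `N=C(N)c1ccc(Oc2ccc(N)c(Oc3ccc(C(=N)N)cc3)n2)cc1` gives 5500 nM. Compound 3 thus has the highest number of the three: the step of a 2.8-fold higher number from compound 2 to compound 3 (0.44 log units; beyond the scatter) and the step of a 3.9-fold higher number from compound 1 to compound 3 (0.59 log units; beyond the scatter) both lie beyond the scatter, whereas the step of a 1.4-fold higher number from compound 1 to compound 2 (0.15 log units; within the scatter) does not.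

Compound 4 `N=C(N)c1ccc(Oc2ccc(C(=O)N3CCC(CCN)CC3)c(Oc3ccc(C(=N)N)cc3)n2)cc1` has not yet been measured in this assay. It differs from compound 3 by (4-(2-aminoethyl)piperidin-1-yl)carbonyl in place of amino on an aromatic carbon. The step that bears on it most closely is a 2.8-fold higher number from compound 2 to compound 3 (0.44 log units; beyond the scatter), in which a carbamoyl group bearing a saturated ring gave way to a bare amino group at the same aromatic carbon. Read in reverse, that step suggests that bringing a carbonyl-linked saturated ring back onto this carbon should lower the number by a modest amount, and the step of a 3.9-fold higher number from compound 1 to compound 3 (0.59 log units; beyond the scatter) points the same way. Compound 4 is therefore expected to show a 2.8-fold lower number from compound 3 to compound 4 (0.44 log units; beyond the scatter). Compound 4 is estimated to give 2000 nM in this assay, with a range from 800 nM to 5000 nM.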

Compound 4, inhibition constant: 3600 nM
The estimate for compound 4 lay 1.8-fold (0.26 log units) below the measured number; measured number inside the range.
By their numbers in this assay, from the lowest: compounds 1, 2, 4 and 3 (each within the scatter of the next, the first and the last beyond it).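

In this assay the (4-(2-aminoethyl)piperidin-1-yl)carbonyl group, with 11 heavy atoms where amino has 1 heavy atom, gives a 1.5-fold lower number from compound 3 to compound 4 (0.18 log units; within the scatter) on this aromatic carbon, so this much larger group cannot be told apart from amino here, which the carbamoyl group of compound 2 could be by a 2.8-fold higher number from compound 2 to compound 3 (0.44 log units; beyond the scatter) in the opposite reading. Changing the group on the carbonyl carbon to 4-(2-aminoethyl)piperidin-1-yl from (4-aminocyclohexyl)amino gives a 1.8-fold higher number from compound 2 to compound 4 (0.26 log units; within the scatter) and so leaves compound 4 inseparable from compound 2 as well, placing it within the scatter of two compounds that are themselves separated. Only the comparison with the ((4-fluorophenyl)sulfonyl)amino group remains clear, as a 2.6-fold higher number from compound 1 to compound 4 (0.41 log units; beyond the scatter) and thus a modest step in favour of that group on this carbon.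

As far as these compounds go, what a plain piperidin-1-yl carbonyl without the 2-aminoethyl chain, a longer chain ending in an amine, or a carboxylic acid would give at this aromatic carbon stays open. Nothing at hand accounts for any of these steps.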